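Methoxy for Methyl on the Aryl Ring of Compound 1

This account rests on a few compounds, and the source may have more. Where it says the series, first, only, none or still open, it means among the compounds named here.

Measured compounds:
compound 1, `CCCC(c1ccccc1)N(CCC)c1nc(-c2ccc(OC)cc2C)n(C)n1`, 61 nM
compound 2, `CCCN(c1nc(-c2ccc(Cl)cc2OC)n(C)n1)C(CC)c1ccc(C(F)(F)F)cc1`, 12 nM

In an in vitro assay on Ltk- cells for binding affinity to corticotropin-releasing factor receptor 1 (Homo sapiens) (on this read-out higher numbers stand for weaker inhibition and lower numbers for stronger inhibition), compound 1 gives 61 nM, the higher of the two numbers. The other measured compound differs from it in several places at once; in this assay compound 2 gives 12 nM, a gap beyond the scatter. Compound 3, `CCCC(c1ccccc1)N(CCC)c1nc(-c2ccc(OC)cc2OC)n(C)n1`, is not yet measured. It differs from compound 1 by methoxy in place of methyl on an aromatic carbon. Going by the values given here, with no single-change step recorded, the size of the step is uncertain; a modest move toward a lower number is expected, a 1.5-fold lower number from compound 1 to compound 3 (0.18 log units; within the scatter), though it may stay within the scatter. Compound 3 is therefore estimated at 40 nM, between 15 nM and 120 nM.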

Compound 3, inhibition constant: 120 nM
Compound 3: middle estimate off by 3.0-fold (0.48 log units), on the low side; measured number inside the range.
By their numbers in this assay, from the lowest: compound 2; then compounds 1 and 3 (each within the scatter of the next).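

In this assay, going by these compounds alone, methoxy in place of methyl on this aromatic carbon, ortho to a large group, gives a 2.0-fold higher number from compound 1 to compound 3 (0.29 log units; within the scatter) and so provides the first single-change reading at this position. The added oxygen leaves the number within the usual scatter, so this swap cannot be told apart from repeat-measurement noise. No available evidence explains the outcome. Going by these compounds, whether an amine or an ethoxy group at this position would move the number beyond the scatter stays open. So does whether this swap behaves alike on other substituted versions of the shared core.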